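Propyl to pentyl on the shared core

This account rests on a few compounds, and the source may have more. Where it says the series, first, only, none or still open, it means among the compounds named here.

In a functional assay on the whole organism with Rattus norvegicus as the target; on this read-out higher numbers stand for an effect only at larger amounts of compound and lower numbers for an effect already at smaller amounts:
- compound 1 `Nc1nc2ccc(I)cc2s1`: > 10 mg/kg, a limit
- compound 2 `Nc1ccc2nc(N)sc2c1`: > 10 mg/kg, a limit
- compound 3 `CCCc1ccc2nc(N)sc2c1`: 6 mg/kg

Only compound 3 gives a number. Compound 1 and compound 2 stand at the limit of > 10 mg/kg in this assay, at which 2 of the 3 values shown sit.

The next compound, compound 4 `CCCCCc1ccc2nc(N)sc2c1`, differs from compound 3 by ethyl in place of hydrogen on a saturated chain carbon, three bonds along the chain from an aromatic carbon, which turns propyl into pentyl.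

Within the data shown here, two measured steps bear on this change, and only indirectly: an at least 1.6-fold lower number from compound 1 to compound 3 (0.22 log units; that floor lies within the scatter) and an at least 1.6-fold lower number from compound 2 to compound 3 (0.22 log units; that floor lies within the scatter). Both floors lie within the scatter. Among the measured compounds shown here, both steps also put propyl in place of another group on an aromatic carbon, and no measured step lengthens a chain. Neither a size nor a direction can therefore be carried over, and no step beyond the scatter is expected in this assay. The expected step is no change at the digits printed from compound 3 to compound 4 (within the scatter). A result reported only as a limit also remains possible for compound 4. The estimate for compound 4 is 6 mg/kg, with an expected range from 2.5 mg/kg to 15 mg/kg.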

Compound 4, dose for half-maximal effect: 7.5 mg/kg
For compound 4 the middle estimate is 1.3-fold (0.10 log units) below the measured one; measured number inside the range.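

In this assay, among these compounds, the change from propyl to pentyl gives a 1.3-fold higher number from compound 3 to compound 4 (0.10 log units; within the scatter) and is the first measured step that lengthens a chain on the shared core, so this extension of the chain leaves no readable change. Set against the amino and iodo compounds, pentyl gives an at least 1.3-fold lower number from compound 2 to compound 4 (0.12 log units; that floor lies within the scatter) and an at least 1.3-fold lower number from compound 1 to compound 4 (0.12 log units; that floor lies within the scatter) and both of these are floors only. Compound 1 and compound 2 remain limits and not numbers, so the true size of these two steps stays hidden: the limit of > 10 mg/kg in this assay, at which 2 of the 4 values shown sit.

Going by these compounds, whether a longer chain such as octyl, or a chain ending in an amine or a carboxylic acid, would still give a number in this assay stays open. On these data alone, a shorter chain such as methyl or ethyl on the same aromatic carbon also remains open.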